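Dihydropyrimidinone amides: cytotoxicity on Vero cells

The source may hold more compounds than are shown below. What is called first, only, known or untested is meant among the compounds shown, and "the series" means these compounds.

Two members of the series have been tested in an ADME assay on Vero cells (Chlorocebus sabaeus) for cytotoxicity, read by XTT assay, with a stated time of 72 h; on this read-out lower numbers stand for higher toxicity in this test and higher numbers for lower toxicity in this test. Compound 1 `CC1=C(C(=O)Nc2ccccc2Cl)C(c2cccc(Br)c2)NC(=O)N1` gives a value that is a limit of the assay, > 100000 nM. Compound 2 `CC1=C(C(=O)Nc2cccnc2)C(c2cccs2)NC(=O)N1` likewise gives only a limit, > 100000 nM. Compound 2 therefore stands at the limit rather than at a number, and the other value shown keeps it company there: both sit at the limit of > 100000 nM in this assay, at which 2 of the 2 values shown sit.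

Compound 3 `CC1=C(C(=O)Nc2ccccc2Cl)C(c2cccs2)NC(=O)N1` has not yet been measured in this assay. It differs from compound 2 in one place, (2-chlorophenyl in place of pyridin-3-yl on an amide-type nitrogen). Going by the values given here, no measured pair isolates this change, so no step size can be read from the data.

The expectation is that the change from compound 2 to compound 3 produces no step beyond the scatter, a step that the limit leaves unreadable from compound 2 to compound 3, because every value shown so far sits at the limit of > 100000 nM in this assay, at which 2 of the 2 values shown sit. For compound 3 the estimate in this assay is 150000 nM, with a range from 80000 nM to 300000 nM, and most likely the assay again reports only a limit.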

Compound 3, half-maximal cytotoxic concentration: > 100000 nM
Compound 3: no number, only a limit; the forecaster's own chance of this, stated with the estimate: 85%; the middle value lies beyond the limit too.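

Compound 3 gives only a limit in this assay, and compound 1 and compound 2 also give only limits, so neither step to compound 3 can be read: the limit of > 100000 nM in this assay, at which 3 of the 3 values shown sit.

The compounds shown leave open whether 2-chlorophenyl in place of pyridin-3-yl, or thiophen-2-yl in place of 3-bromophenyl, changes this read-out at all.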